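Swapping the sulfonyl cap in a platelet inhibition series

The source may report more compounds than this note shows. Statements on the series, on what has been measured and on what is new or still open speak of the compounds shown alone.

Measured compounds:
- Compound 1, `N#Cc1cc2c(nc1N1CCC(C(=O)NS(=O)(=O)C(F)(F)c3ccccc3)CC1)COC2=O`: "not determined" (no result reported) in a functional assay (Platelet, plasma) for inhibition, with Homo sapiens as the target; on this read-out higher numbers stand for weaker inhibition and lower numbers for stronger inhibition
- Compound 2, `N#Cc1cc2c(nc1N1CCC(C(=O)NS(=O)(=O)c3ccc(Cl)s3)CC1)COC2=O`: 4470 nM

Among the measured compounds shown here, compound 2 is the only compound in this set with a numerical value, so there is no comparison available among measured compounds; compound 1 carries no reported result in this assay. Compound 3, `N#Cc1cc2c(nc1N1CCC(C(=O)NS(=O)(=O)C3(c4ccccc4)CC3)CC1)COC2=O`, is yet to be tested. It differs from compound 2 in one place: 1-phenylcyclopropyl in place of 5-chlorothiophen-2-yl on a sulfonyl sulfur. The rest of the molecule, including the shared core and the amide-type nitrogen on the sulfonyl sulfur, is unchanged.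

For the measured compounds named here, with no measured pair that isolates this kind of change, the expectation for this assay rests on compound 2 alone. The change is expected to bring no shift beyond the usual scatter, and any drift is expected to be toward slightly weaker inhibition. On that basis compound 3 is estimated at 6000 nM, within a range from 1500 nM to 25000 nM, which corresponds to an expected step of a 1.3-fold higher number from compound 2 to compound 3 (0.13 log units; within the scatter).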

Compound 3, half-maximal inhibitory concentration: 4100 nM
Estimate against measurement, compound 3: 1.5-fold (0.17 log units) above, within the range that was stated.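

In this assay, among the compounds shown here, placing 1-phenylcyclopropyl instead of 5-chlorothiophen-2-yl on the sulfonyl sulfur gives a 1.1-fold lower number from compound 2 to compound 3 (0.04 log units; within the scatter), so this pair gives the first direct reading of a change at this position. The two caps differ considerably, one being a five-membered aromatic ring carrying sulfur and chlorine and the other an all-carbon group with a three-membered ring and a six-membered aromatic ring, yet the two compounds cannot be told apart on this read-out. The data offer no measured explanation for this match.

Still open, on these data alone, is whether a cap of another kind on the sulfonyl sulfur, such as a plain methyl group or a phenyl ring bearing an amine or a carboxylic acid, would move the number beyond the scatter. Also open, as far as these compounds go, is whether this swap would read the same way on a different core.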